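A few compounds are considered here, and "the series" means these few. Any claim that something is new, unique, unknown or untested is made for them only; others in the source may bear on it.

Working notes on the amide series, read in an in vivo functional assay on the whole organism for inhibition, with Rattus norvegicus as the target (on this read-out higher numbers stand for an effect only at larger amounts of compound and lower numbers for an effect already at smaller amounts), throughout. On the shared core, compound 1 `CCCCc1nc(C)c(CC(=O)N(CC)CC)c(=O)n1Cc1ccc(-c2ccccc2-c2nnn[nH]2)cc1` gives 0.089 mg/kg and compound 2 `CCCCc1nc(C)c(CC(=O)N2CCC[C@H]2C(N)=O)c(=O)n1Cc1ccc(-c2ccccc2-c2nnn[nH]2)cc1` gives 0.023 mg/kg while compound 3 `CCCCc1nc(C)c(CC(=O)N2CCSCC2)c(=O)n1Cc1ccc(-c2ccccc2-c2nnn[nH]2)cc1` gives 0.038 mg/kg on the same read-out. Two steps place the last of these: a 1.7-fold higher number from compound 2 to compound 3 (0.22 log units; within the scatter) on one side and a 2.3-fold lower number from compound 1 to compound 3 (0.37 log units; beyond the scatter) on the other. The next change sits on a carbonyl carbon: 2,6-dimethylmorpholin-4-yl in place of thiomorpholin-4-yl on a carbonyl carbon and this gives compound 4 `CCCCc1nc(C)c(CC(=O)N2CC(C)OC(C)C2)c(=O)n1Cc1ccc(-c2ccccc2-c2nnn[nH]2)cc1` with the rest of the structure kept. Within the data shown here, no measured step tests this pair of groups directly. The nearest evidence is the other swaps at that carbonyl carbon, where a 3.9-fold lower number from compound 1 to compound 2 (0.59 log units; beyond the scatter) is modest as well. Starting from compound 3 at 0.038 mg/kg and with the ring swap of a 1.7-fold higher number from compound 2 to compound 3 (0.22 log units; within the scatter) inside the scatter, no step beyond the scatter is expected in this assay for this change. The expected step is a 1.1-fold higher number from compound 3 to compound 4 (0.02 log units; within the scatter) as estimated here. Compound 4 is estimated at 0.04 mg/kg with an expected range from 0.015 mg/kg to 0.11 mg/kg for the coming measurement.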

Compound 4, dose for half-maximal effect: 0.029 mg/kg
The estimate for compound 4 lay 1.4-fold (0.14 log units) above the measured number, within the range that was stated.
By their numbers in this assay, from the lowest: compounds 2, 4 and 3 (each within the scatter of the next); then compound 1.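

In this assay, 2,6-dimethylmorpholin-4-yl on a carbonyl carbon gives a 1.3-fold lower number from compound 3 to compound 4 (0.12 log units; within the scatter) and a 1.3-fold higher number from compound 2 to compound 4 (0.10 log units; within the scatter), both within the scatter, so a third ring group joins thiomorpholin-4-yl and 2-carbamoylpyrrolidin-1-yl at this position with no separation among them. Against diethylamino the change gives a 3.1-fold lower number from compound 1 to compound 4 (0.49 log units; beyond the scatter), so among these four compounds all three ring groups stand apart from the open-chain group, with no compound going against this. No measurement at hand explains these steps.

On these data alone, whether the two methyl groups contribute stays open, and plain morpholin-4-yl on the same carbonyl carbon would address that. A piperazin-1-yl with its free amine, or a ring bearing a carboxylic acid, would show whether this tolerance extends further.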